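The compounds below may be only part of what the source reports. "The series", "measured", "known", "first", "only" and "open" are said of these compounds alone.

Measured in a functional assay on PC-3 cells (Homo sapiens) for antiproliferative activity, read by MTT assay, with a stated time of 48 h; on this read-out higher numbers stand for weaker inhibition and lower numbers for stronger inhibition:
- compound 1 `CCN(CC)CCNC(=O)c1ccc(C(CC)(CC)c2ccc(OCCC(O)(CC)CC)c(C)c2)n1CC`: 3350 nM
- compound 2 `CCn1c(C(=O)Nc2cccc(C(F)(F)F)c2)ccc1C(CC)(CC)c1ccc(OCCC(O)(CC)CC)c(C)c1`: 23800 nM
- compound 3 `CCn1c(C(=O)N(C)CC(=O)O)ccc1C(CC)(CC)c1ccc(OCCC(O)(CC)CC)c(C)c1`: 2250 nM

Compound 3 at 2250 nM cannot be separated from compound 1, as the step of a 1.5-fold lower number from compound 1 to compound 3 (0.17 log units; within the scatter) shows. Compound 2 stands clearly apart from both, with a 7.1-fold higher number from compound 1 to compound 2 (0.85 log units; beyond the scatter) and an 11-fold lower number from compound 2 to compound 3 (1.02 log units; beyond the scatter).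

Next in the series is compound 4 `CCn1c(C(=O)NC(C)CO)ccc1C(CC)(CC)c1ccc(OCCC(O)(CC)CC)c(C)c1`, with the change ((1-(hydroxymethyl)ethyl)amino in place of (carboxymethyl)(methyl)amino on a carbonyl carbon). The exchange takes place on a carbonyl carbon, and neither the leaving nor the entering group has a ring. Within the data shown here, no measured compound carries (1-(hydroxymethyl)ethyl)amino, so the data contain no direct precedent for this group.

The closest guide is a 1.5-fold lower number from compound 1 to compound 3 (0.17 log units; within the scatter), an exchange between two groups without a ring on the same carbonyl carbon. Among the measured compounds shown here, the two large steps both involve 3-(trifluoromethyl)phenyl, which has no counterpart in compound 4, so they bear on this change only weakly. With just three measured compounds, the basis is thin and the range has to stay wide.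

No step beyond the scatter is expected in this assay. The expected step is a 1.3-fold higher number from compound 3 to compound 4 (0.12 log units; within the scatter). For compound 4 the estimated value is 3000 nM, with an expected range from 1100 nM to 8500 nM.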

Compound 4, half-maximal inhibitory concentration: 7870 nM
Compound 4: the middle estimate sits 2.6-fold (0.42 log units) below what was measured; low and high end bracket the measured number.
By their numbers in this assay, from the lowest: compounds 3 and 1 (each within the scatter of the next); then compound 4; then compound 2.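

In this assay the exchange of (carboxymethyl)(methyl)amino for (1-(hydroxymethyl)ethyl)amino on the carbonyl carbon gives a 3.5-fold higher number from compound 3 to compound 4 (0.54 log units; beyond the scatter) and shows that two groups without a ring can differ here by more than the scatter, which compound 1 and compound 3 alone did not show. The comparison with the diethylamino side chain points the same way, with a 2.3-fold higher number from compound 1 to compound 4 (0.37 log units; beyond the scatter), so the absence of a ring does not by itself place a compound level with compound 1 and compound 3. Compound 4 also stays apart from the 3-(trifluoromethyl)phenyl amide, with a 3.0-fold lower number from compound 2 to compound 4 (0.48 log units; beyond the scatter), which gives this position three levels instead of a plain split between that amide and the rest.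

The exchange removes the carboxylic acid and the methyl on the amide nitrogen and brings in a hydroxyl chain all at once, and the step cannot be assigned to any one of these; (carboxymethyl)amino, without the methyl, or (2-hydroxyethyl)amino, with a shorter chain, would pull these parts apart. Nothing at hand gives a reason for the size of these steps.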